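A few compounds are considered here, and "the series" means these few. Any claim that something is new, unique, unknown or untested is made for them only; others in the source may bear on it.

In an assay on isolated protein for inhibition of complement C1r subcomponent (Homo sapiens) (on this read-out lower numbers stand for stronger inhibition and higher numbers for weaker inhibition), compound 1 `O=c1oc(Nc2ccccc2Br)nc2ccccc12` gives 5100 nM, and compound 2 `Cc1ccccc1Nc1nc2ccccc2c(=O)o1` gives 31000 nM, the higher of the two numbers. For the measured compounds named here, the one step so far, a 6.1-fold higher number from compound 1 to compound 2 (0.78 log units; beyond the scatter), came from methyl in place of bromo on an aromatic carbon. Compound 3 `CSc1ccccc1Nc1nc2ccccc2c(=O)o1` carries methylsulfanyl in place of methyl on an aromatic carbon. Since the bromo group of compound 1, at 5100 nM, gave a lower number than the methyl of compound 2, a somewhat larger group in this place is expected to lower the number again, though by less than that step, so a modest drop a 2.1-fold lower number from compound 2 to compound 3 (0.32 log units; beyond the scatter) is anticipated. Compound 3 is estimated at 15000 nM, within 4000 nM to 50000 nM.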

Compound 3, half-maximal inhibitory concentration: > 62500 nM
Compound 3: no number, only a limit; the forecaster's own chance of this, stated with the estimate: 10%; middle value at least 4.1-fold (0.61 log units) away from the limit.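

Compound 3 gives no number in this assay, only a limit: the limit of > 62500 nM in this assay, at which 1 of the 3 values shown sits. Methylsulfanyl in place of methyl gives an at least 2.0-fold higher number from compound 2 to compound 3 (0.30 log units; that floor lies within the scatter), so this floor alone does not separate the two groups, while methylsulfanyl in place of bromo gives an at least 12-fold higher number from compound 1 to compound 3 (1.08 log units; beyond the scatter). At this place, then, a group with more heavy atoms than methyl did not bring the number down, and bromo keeps the lowest number of the three. On these data alone, how far compound 3 lies beyond its limit remains open, as does whether chloro, methoxy or an amine here would match bromo.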